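Capping the Phenol of Compound 3

The compounds below may be only part of what the source reports. "The series", "measured", "known", "first", "only" and "open" are said of these compounds alone.

In a functional assay on the whole organism for inhibition, with Amaranthus hypochondriacus as the target (a lower number here means a stronger inhibitor, a higher number a weaker inhibitor), compound 3 `CC(=O)c1cc2c(cc1O)OC(C)(C)C=C2` gives 27 ug/mL, the lowest of the three numbers in hand. Compound 1 `C=C(C)[C@@H]1Oc2cc(O)c(C(C)=O)cc2[C@H]1OC` gives 61 ug/mL and compound 2 `COC(C)(C)/C=C/c1cc(C(C)=O)ccc1O[C@@H]1O[C@H](CO)[C@@H](O)[C@H](O)[C@H]1O` gives 148 ug/mL; both lie beyond the scatter from compound 3, compound 1 the nearer and compound 2 the further. Compound 4 `COc1cc2c(cc1C(C)=O)C=CC(C)(C)O2` has not yet been tested in this assay. It differs from compound 3 in a single place: methyl in place of hydrogen on an oxygen on an aromatic ring. Among the measured compounds shown here, no measured pair shows this change on its own, so its step is unknown. The expectation is a moderate move toward a higher number. Compound 4 is thus expected to give 55 ug/mL, within 22 ug/mL to 140 ug/mL. The estimated step of a 2.0-fold higher number from compound 3 to compound 4 (0.31 log units; beyond the scatter) would stand just beyond the scatter.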

Compound 4, half-maximal inhibitory concentration: 7 ug/mL
Compound 4: middle estimate off by 7.9-fold (0.90 log units), on the high side; the whole stated range lies above it.
By their numbers in this assay, from the lowest: compound 4; then compound 3; then compound 1; then compound 2.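

Placing methyl on the oxygen on the aromatic ring does not cost activity in this assay: the change from hydroxy to methoxy gives a 3.9-fold lower number from compound 3 to compound 4 (0.59 log units; beyond the scatter) and lies beyond the scatter. Among the compounds shown here, a free hydroxy at this place is therefore not required for inhibition on this core, something no earlier compound could show, as this is the first step that changes one place alone. Nothing at hand accounts for the gain.

On these data alone, whether an ethyl group or a longer chain on this oxygen would lower the number further stays open. So does whether hydroxy to methoxy acts the same way on the core of compound 1.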